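Chain extension from compound 1 to compound 4: cytotoxicity notes

The source may report more compounds than this note shows. Statements on the series, on what has been measured and on what is new or still open speak of the compounds shown alone.

Of the compounds shown here, three of the shared core have been read in an ADME assay on MDCK cells (Canis lupus familiaris) for cytotoxicity, read by microscopy, with a stated time of 48 h (on this read-out higher numbers stand for lower toxicity in this test and lower numbers for higher toxicity in this test), so far. Compound 1 `CCCc1csc(CN[C@@H]2C[C@H]3C[C@@H]([C@H]2C)C3(C)C)c1` carries a propyl chain on its aromatic ring; in this assay compound 1 gives 12500 nM. Compound 2 `C[C@H]1[C@H](NCc2sccc2-c2ccsc2)C[C@H]2C[C@@H]1C2(C)C`, which carries a second aromatic ring in place of that chain, gives 12500 nM in this assay, so compound 1 sits level with compound 2 at the digits shown, within the usual scatter. Compound 3 `C[C@H]1[C@H](NCc2nccs2)C[C@H]2C[C@@H]1C2(C)C` returns only a limit in this assay, > 100000 nM, and not a number; the evidence on this set notes (the limit of > 100000 nM in this assay, at which 1 of the 3 values shown sits). For the measured compounds named here, no step between measured compounds that differ in one place is available, so no measured step sets a scale for the change considered here.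

Compound 4 `CCCCc1csc(CN[C@@H]2C[C@H]3C[C@@H]([C@H]2C)C3(C)C)c1` is the next entry for this assay. Relative to compound 1 the change is methyl in place of hydrogen on a saturated chain carbon, three bonds along the chain from an aromatic carbon. With the two substituted compounds 1 and 2 lying level and only compound 3 at the limit, the step from propyl to butyl is expected to stay within the scatter, and the change no change at the digits printed from compound 1 to compound 4 (within the scatter) is the estimate adopted. For compound 4 the expected value in this assay is 12500 nM, with a range from 4000 nM to 40000 nM.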

Compound 4, minimum cytotoxic concentration: 12500 nM
Compound 4: the middle estimate sits on the measured number at the digits printed; the measured number falls inside the stated range.
By their numbers in this assay, from the lowest: compounds 1, 2 and 4 (each within the scatter of the next). At a limit, above all of these: compound 3.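

In this assay, the first step measured on this chain reads no change at the digits printed from compound 1 to compound 4 (within the scatter). This gives the series its first scale for a change in one place: methyl in place of hydrogen on a saturated chain carbon, three bonds along the chain from an aromatic carbon, here taking propyl to butyl, and the step stays within the scatter. For the compounds shown here, the earlier compounds offered no such step, so this reading is the first to bear on the end of the chain alone, though it covers one position and one change only.

From the compounds shown here alone, whether the reading stays flat for a shorter chain such as ethyl, for a longer chain such as hexyl, or with an amine or a carboxylic acid at the chain end remains open, as a single step sets no trend. Compound 3 stands only as a limit and not as a number, and no step in one place links it to the chain compounds, so what sets it apart from them cannot be read from this set: the limit of > 100000 nM in this assay, at which 1 of the 4 values shown sits.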